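Lengthening the chain of a propargylamine aryl ether

This account rests on a few compounds, and the source may have more. Where it says the series, first, only, none or still open, it means among the compounds named here.

Compound 1 `C#CCN(C)CCCCCOc1cccc(OC)c1` and compound 2 `C#CCN(C)CCCCOc1ccc(C=O)c(OC)c1` both carry a propargylamine on a saturated chain joined through an ether oxygen to a methoxy-bearing aromatic ring. In an ADME assay on BTI cells for inhibition of Amine oxidase [flavin-containing] A (Homo sapiens), read by fluorescence and Amplex Red, with a stated time of 15 min, tested at 100 uM (on this read-out lower numbers stand for less inhibition and higher numbers for more inhibition at the one concentration tested (going by the name of the read-out)), compound 1 gives 32.3%, and compound 2 gives 29.4%. Within the data shown here, compound 2 holds the lower of the two numbers, yet compound 1, its only neighbour, sits within the scatter of it, so the pair cannot be told apart. Compound 3 `C#CCN(C)CCCCCOc1ccc(C=O)c(OC)c1` has not yet been measured in this assay. It differs from compound 2 by (methyl(propargyl)amino)methyl in place of methyl(propargyl)amino on a saturated chain carbon, four bonds along the chain from an oxygen on an aromatic ring. Among the measured compounds shown here, no measured pair isolates this change, and the two known values offer no direction for it. Only a small movement, none beyond the scatter, is expected, with the estimated step being a number 1.6 percentage points higher from compound 2 to compound 3 (within the scatter). In this assay compound 3 is therefore estimated at 31%, within a range from 18% to 44%.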

Compound 3, a percentage reported as inhibition, at one concentration (the size of the read-out at that concentration, not a potency): 27.1%
Compound 3: middle estimate off by 3.9 percentage points, on the high side; measured number inside the range.
By their numbers in this assay, from the lowest: compounds 3, 2 and 1 (each within the scatter of the next).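

In this assay the two new pairs each isolate one change: (methyl(propargyl)amino)methyl in place of methyl(propargyl)amino on a saturated chain carbon, four bonds along the chain from an oxygen on an aromatic ring, gives a number 2.3 percentage points lower from compound 2 to compound 3 (within the scatter) and formyl in place of hydrogen on an aromatic carbon gives a number 5.2 percentage points lower from compound 1 to compound 3 (within the scatter) so both sites now have a measured comparison. Neither change moves the read-out beyond the usual scatter at the one concentration tested. Nothing available here explains these results.

As far as these compounds go, it remains open whether a longer chain, such as 2-(methyl(propargyl)amino)ethyl, would move the number beyond the scatter. The same question stands for a carboxylic acid or an amine in place of the formyl group on that aromatic carbon.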